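The source may report more compounds than this note shows. Statements on the series, on what has been measured and on what is new or still open speak of the compounds shown alone.

Measured so far:
compound 1, `CCCn1c(=O)c2[nH]c(Cc3ccccc3)nc2n(Cc2ccco2)c1=O`: 302 nM
compound 2, `CCn1c(=O)c2c(nc(Cc3ccccc3)n2C)n(Cc2ccco2)c1=O`: 28.8 nM

In an assay on cell membranes for displacement of a labelled ligand from adenosine receptor A1 (Rattus norvegicus) (on this read-out lower numbers stand for stronger inhibition and higher numbers for weaker inhibition), compound 2 gives the lower of these two numbers, and the gap to compound 1 lies well beyond the usual scatter. Compound 3, `CCCn1c(=O)c2c(nc(Cc3ccccc3)n2C)n(Cc2ccco2)c1=O`, has not been measured. It differs from compound 2 by methyl in place of hydrogen on a saturated chain carbon, two bonds along the chain from an aromatic nitrogen; cut one bond further out, the change reads ethyl to propyl. Among the compounds with values here, compound 1 also carries the propyl chain but differs in other places too, so no single step shows this change on its own. The step expected here is small, a 1.4-fold lower number from compound 2 to compound 3 (0.16 log units; within the scatter), hardly beyond the scatter. Compound 3 is therefore estimated at 20 nM, within a range from 7 nM to 60 nM.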

Compound 3, inhibition constant: 26.9 nM
Beside the measured number, compound 3's estimate is 1.3-fold (0.13 log units) below it, within the range that was stated.
By their numbers in this assay, from the lowest: compounds 3 and 2 (each within the scatter of the next); then compound 1.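

In this assay, ethyl and propyl on this chain carbon cannot be told apart, with a 1.1-fold lower number from compound 2 to compound 3 (0.03 log units; within the scatter). Within the data shown here, compound 3 also gives the first comparison that differs in one place for the other site: methyl in place of hydrogen on an aromatic nitrogen goes with an 11-fold lower number from compound 1 to compound 3 (1.05 log units; beyond the scatter), a step that the chain change does not approach. No measurement shown here gives an explanation for either step.

From the compounds shown here alone, it remains open whether a butyl chain, or a chain ending in an amine, would fit this position equally well. Whether ethyl in place of that methyl on the aromatic nitrogen would hold the same level is also unknown.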